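A Mirror-Image Centre in a Bisphosphate Series

This account rests on a few compounds, and the source may have more. Where it says the series, first, only, none or still open, it means among the compounds named here.

In a functional assay for inhibition, with Rattus norvegicus as the target (a higher number here means a weaker inhibitor, a lower number a stronger inhibitor), three compounds have been measured. Compound 1 (`CNc1nc(Cl)nc2c1ncn2[C@H]1CC(OC(C)=O)[C@]2(COP(=O)(O)O)CC12`) gives 10000 nM, and compound 2 (`CNc1nc(Cl)nc2c1ncn2CC(COP(=O)(O)O)COP(=O)(O)O`) gives 300 nM. Compound 3 (`CNc1nc(Cl)nc2c1ncn2C[C@H](COP(=O)(O)O)OP(=O)(O)O`) gives 2600 nM, the middle number of the three. It is a weaker inhibitor than compound 2 and a stronger one than compound 1, and both gaps lie beyond the usual scatter.

The next compound is compound 4 (`CNc1nc(Cl)nc2c1ncn2C[C@@H](COP(=O)(O)O)OP(=O)(O)O`), which differs from compound 3 as follows: the two compounds have the same atoms and bonds and differ only in configuration as drawn: 1 of 1 stereo elements differ; a stereocentre at a saturated chain carbon is drawn R in compound 3 and S in compound 4. Within the data shown here, no measured pair in this set isolates a change of configuration, so the size of this step cannot be read from the data. The spread of the three measured values shows only that this assay responds to changes in the compounds, and those changes are larger than this one. An estimated step of a 2.2-fold lower number from compound 3 to compound 4 (0.34 log units; beyond the scatter) is expected, a modest move towards a lower number, with little confidence in its direction. For compound 4 the expected value is 1200 nM, with an estimated range of 250 nM to 6000 nM.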

Compound 4, inhibition constant: 1400 nM
The estimate for compound 4 lay 1.2-fold (0.07 log units) below the measured number; low and high end bracket the measured number.
By their numbers in this assay, from the lowest: compound 2; then compounds 4 and 3 (each within the scatter of the next); then compound 1.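

Among these compounds, compounds 3 and 4 give the first direct reading of a change of configuration, at the stereocentre on the saturated chain carbon. In this assay the reading is a 1.9-fold lower number from compound 3 to compound 4 (0.27 log units; within the scatter), so drawing this centre R or S does not separate the two compounds in this assay. The comparison is a clean one, as no other part of the structure changes: the fact that compounds 3 and 4 differ only in the configuration as drawn

From the compounds shown here alone, it remains open whether the configuration at this carbon would still make so little difference in a compound with a different group in place of one of the phosphates, such as a carboxylic acid or a phosphonate. A longer chain between the shared core and the stereocentre is a second open case, since this pair speaks only for the chain it carries.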